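Swapping the nitro-bearing ring in an acylurea series

The compounds below may be only part of what the source reports. "The series", "measured", "known", "first", "only" and "open" are said of these compounds alone.

Measured so far:
- compound 1 `CN(C(=O)NC(=O)c1ccc([N+](=O)[O-])cc1)c1nc(C(F)(F)F)c(C(=O)N/N=C/c2cccc(C(F)(F)F)c2)s1`: 4.12 ug/mL
- compound 2 `CN(C(=O)NC(=O)c1ccc([N+](=O)[O-])cc1)c1nc(C(F)(F)F)c(C(=O)N/N=C/c2ccc([N+](=O)[O-])cc2)s1`: 8.42 ug/mL
- compound 3 `CN(C(=O)NC(=O)c1ccc(Cl)c(Cl)c1)c1nc(C(F)(F)F)c(C(=O)N/N=C/c2cccc([N+](=O)[O-])c2)s1`: 6.56 ug/mL

These three compounds share one core and were tested in a functional assay on HeLa cells (Homo sapiens) for inhibition, read by MTT assay, with a stated time of 72 h; a higher number here means a weaker inhibitor, a lower number a stronger inhibitor. Compound 1 gives the lowest of the three numbers; its gap to compound 3 lies within the scatter, while the step of a 2.0-fold higher number from compound 1 to compound 2 (0.31 log units; beyond the scatter) lies beyond it.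

Compound 4 `CN(C(=O)NC(=O)c1ccccc1F)c1nc(C(F)(F)F)c(C(=O)N/N=C/c2cccc(C(F)(F)F)c2)s1` has not yet been measured. It differs from compound 1 in one place: 2-fluorophenyl in place of 4-nitrophenyl on a carbonyl carbon. The change sits on a carbonyl carbon whose other neighbour is an amide-type nitrogen, on the side of the molecule opposite to where compound 1 and compound 2 differ.

Among the measured compounds shown here, no measured step isolates a change at this position. The step of a 2.0-fold higher number from compound 1 to compound 2 (0.31 log units; beyond the scatter) concerns the other aryl ring and so does not bear directly on it. Compound 3 carries a different ring on the same carbonyl carbon, but it also differs at the second ring, so only its value can be compared with that of compound 1, and the two lie within the scatter of each other.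

For the measured compounds named here, with no step speaking to this change, compound 4 is expected to stay close to compound 1, with a 1.2-fold higher number from compound 1 to compound 4 (0.08 log units; within the scatter) no larger than the scatter. The estimate for compound 4 is 5 ug/mL, within a range from 2.5 ug/mL to 10 ug/mL.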

Compound 4, half-maximal inhibitory concentration: 19.1 ug/mL
For compound 4 the middle estimate is 3.8-fold (0.58 log units) below the measured one; the whole stated range lies below it.
By their numbers in this assay, from the lowest: compounds 1, 3 and 2 (each within the scatter of the next, the first and the last beyond it); then compound 4.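

Among the compounds shown here, this is the first step that isolates the aryl ring on the carbonyl carbon whose other neighbour is an amide-type nitrogen. With the rest of the molecule held constant in this assay, the exchange gives a 4.6-fold higher number from compound 1 to compound 4 (0.67 log units; beyond the scatter), which shows that the read-out is sensitive to the group at this position, just as a 2.0-fold higher number from compound 1 to compound 2 (0.31 log units; beyond the scatter) shows for the other aryl ring. The data shown offer no measured explanation for this shift, and a single exchange cannot separate the loss of the nitro group from the arrival of the fluorine or from the different placement of the substituent on the ring.

A plain phenyl ring, a 4-fluorophenyl ring or a 4-aminophenyl ring on the same carbonyl carbon would help to show which part of the exchange matters, but the compounds shown do not include these groups. Going by these compounds, it also remains open whether 2-fluorophenyl in place of 4-nitrophenyl would give a similar step when the other aryl ring is the 4-nitrophenyl of compound 2.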